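The source may report more compounds than this note shows. Statements on the series, on what has been measured and on what is new or still open speak of the compounds shown alone.

Measured so far in a functional assay on LoVo cells (Homo sapiens) for antiproliferative activity, read by MTT assay, with a stated time of 72 h; on this read-out lower numbers stand for stronger inhibition of growth and higher numbers for weaker inhibition of growth:

Compound 1 `COc1cc(OC)n2cc(-c3ccc(N)cc3)nc2n1` gives > 100000 nM, which is a limit of the assay rather than a number.
Compound 2 `COc1cc(OC)n2cc(-c3ccc(NCc4ccccc4)cc3)nc2n1` gives > 100000 nM, again a limit of the assay.
Compound 3 `Cc1ccc2nc(-c3ccc(N)cc3)cn2c1` gives 65200 nM.

Compound 2 arises from compound 1 by the change (benzyl in place of hydrogen on a nitrogen on an aromatic ring). The step that the two limits leave unreadable from compound 1 to compound 2 cannot be read, since both values sit at the limit of > 100000 nM in this assay, at which 2 of the 3 values shown sit. The difference between the core of compound 1 and the core of compound 3 is not broken down here.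

Compound 4 `Cc1ccc2nc(-c3ccc(NCc4ccccc4)cc3)cn2c1` is not yet measured; it arises from compound 3 by the same change, (benzyl in place of hydrogen on a nitrogen on an aromatic ring). Because compound 3 shows a number, 65200 nM, the step to compound 4 can be read once measured, and its size is expected to be a 1.3-fold lower number from compound 3 to compound 4 (0.12 log units; within the scatter), an expectation resting on little, since the earlier step is unreadable.

Compound 4 is expected to give about 50000 nM in this assay, within 10000 nM to 150000 nM.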

Compound 4, concentration for 50% growth inhibition: 42600 nM
Compound 4: middle estimate off by 1.2-fold (0.07 log units), on the high side, within the range that was stated.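

In this assay, benzyl in place of hydrogen on the nitrogen gives a 1.5-fold lower number from compound 3 to compound 4 (0.18 log units; within the scatter), so on this core the change cannot be told apart from the ordinary spread of repeated measurements. One step on one core says little about how this change carries from one core to another. The matching step from compound 1 to compound 2 cannot be read, since both compounds sit at a limit of the assay rather than at a number: the limit of > 100000 nM in this assay, at which 2 of the 4 values shown sit.

As far as these compounds go, it remains open whether a different group on that nitrogen, such as an acetyl group or a longer alkyl chain, would give a step beyond the scatter on the core of compound 3. From the compounds shown here alone, it also remains open whether a carboxylic acid on the benzyl ring would do so.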